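Swapping a Methylsulfonyl for an Acetyl on a Ring Nitrogen

The source may hold more compounds than are shown below. What is called first, only, known or untested is meant among the compounds shown, and "the series" means these compounds.

Compounds 1, 2 and 3 share one core and differ only in one outer group. In a functional assay on MV4-11 cells (Homo sapiens) for antiproliferative activity, with a stated time of 6 days, tested at 1.56 uM (on this read-out higher numbers stand for a stronger effect at the one concentration tested and lower numbers for a weaker effect), compound 1 `CNC(=O)N1CCCc2ccc(NC(=O)c3ccc(-c4ccn(C)n4)cc3)cc21` gives 72.2% and compound 2 `CNC(=O)N1CCCc2ccc(NC(=O)c3cccc(-c4cnn(C)c4)c3)cc21` gives 71.2%. Going by the values given here, compound 3 `CNC(=O)N1CCCc2ccc(NC(=O)c3cccc(-c4ccn(S(C)(=O)=O)n4)c3)cc21` gives 4.03%, the lowest of the three numbers, and the step of a number 67.2 percentage points lower from compound 2 to compound 3 (beyond the scatter) is the one measured step that bears on it. Compound 4 `CNC(=O)N1CCCc2ccc(NC(=O)c3cccc(-c4ccn(C(C)=O)n4)c3)cc21` differs from compound 3 by acetyl in place of methylsulfonyl on an aromatic nitrogen. Among the compounds with values here, no measured step exchanges a methylsulfonyl for an acetyl, so the expectation rests on compound 3, whose 4.03% sits far below the other two. The estimate for compound 4 is a modest rise, a number 11 percentage points higher from compound 3 to compound 4 (beyond the scatter), with an expected value of 15% in a range from 0% to 50%.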

Compound 4, a percentage reported as inhibition, at one concentration (the size of the read-out at that concentration, not a potency): 27.6%
Estimate against measurement, compound 4: 12.6 percentage points below; low and high end bracket the measured number.
By their numbers in this assay, from the lowest: compound 3; then compound 4; then compounds 2 and 1 (each within the scatter of the next).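

Changing only the group on the aromatic nitrogen moves the read-out, with a number 23.6 percentage points higher from compound 3 to compound 4 (beyond the scatter), so methylsulfonyl at this position counts for part of the low number of compound 3. Acetyl does not close the gap, with a number 43.6 percentage points lower from compound 2 to compound 4 (beyond the scatter), though that step also swaps 1-methyl-1H-pyrazol-4-yl for a differently attached ring, so the two changes cannot be separated. Nothing shown explains why either group behaves as it does. Open, on these data alone, is how a propanoyl group or a plain hydrogen on that nitrogen would compare.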